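The source may report more compounds than this note shows. Statements on the series, on what has been measured and on what is new or still open speak of the compounds shown alone.

Compound 1 `O=C1c2c(ccc(O)c2O)CN1Cc1ccc(F)cc1`: "not determined" (no result reported)
Compound 2 `O=C1c2c(ccc(O)c2O)CN1Cc1cccc(Cl)c1`: 9020 nM
Compound 3 `O=C1c2c(ccc(O)c2O)CN1Cc1ccc(F)c(F)c1`: 9010 nM

In an ADME assay on HOS cells (Homo sapiens) for cytotoxicity (a lower number here means a stronger inhibitor, a higher number a weaker inhibitor), compound 3 gives 9010 nM, level within the scatter with compound 2 at 9020 nM, while compound 1 has no number to compare. Compound 4 `O=C1c2c(ccc(O)c2O)CN1Cc1ccc(F)c(Cl)c1` keeps the shared core and is still unmeasured. It differs from compound 3 by chloro in place of fluoro on an aromatic carbon, with chloro in place of fluoro on an aromatic carbon. Among the measured compounds shown here, no measured pair isolates such a change, so the guide is indirect: compound 2, which also carries a chloro group, gives 9020 nM. No shift beyond the scatter is therefore expected in this assay. The expected 1.1-fold lower number from compound 3 to compound 4 (0.05 log units; within the scatter) is small. The estimated value for compound 4 is 8000 nM, with an expected range of 4000 nM to 16000 nM.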

Compound 4, half-maximal inhibitory concentration: 6870 nM
The estimate for compound 4 lay 1.2-fold (0.07 log units) above the measured number; the range from low to high includes it.
By their numbers in this assay, from the lowest: compounds 4, 3 and 2 (each within the scatter of the next).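

In this assay, the swap of chloro in place of fluoro on this aromatic carbon now has a direct pair, and it stays small: a 1.3-fold lower number from compound 3 to compound 4 (0.12 log units; within the scatter). Fluoro in place of hydrogen on an aromatic carbon also stays small, with a 1.3-fold lower number from compound 2 to compound 4 (0.12 log units; within the scatter), so neither single change separates these compounds. No further measurement is available to explain this result.

The compounds shown leave open whether a group other than a halogen at this position, such as an amine, a carboxylic acid or a longer chain, would give a step beyond the scatter.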